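The source may hold more compounds than are shown below. What is called first, only, known or untested is meant among the compounds shown, and "the series" means these compounds.

Compound 1 `COc1ccc(CNc2nc([Se]C)nc3ccccc23)cc1` was tested in an ADME assay on BEAS-2B cells (Homo sapiens) for cytotoxicity, read by MTT assay, with a stated time of 72 h; a lower number here means a stronger inhibitor of growth, a higher number a weaker inhibitor of growth. In this assay compound 1 gives > 100000 nM, which is a limit of the assay rather than a number. Compound 2 `COc1ccc(CNc2nc([SeH])nc3ccccc23)cc1` differs from compound 1 by hydrogen in place of methyl on a selenium. In this assay compound 2 gives > 100000 nM, again a limit. The step that the two limits leave unreadable from compound 1 to compound 2 therefore cannot be read. Compound 3 `CSc1nc(NCc2ccc([Se]C)cc2)c2ccccc2n1` was also tested. In this assay compound 3 gives > 100000 nM, also a limit. Among the measured compounds shown here, compound 1 thus stands where every measured compound stands, at the limit of > 100000 nM in this assay, at which 3 of the 3 values shown sit, and no measured step gives a readable size.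

Compound 4 `C[Se]c1nc(NCc2ccccc2)c2ccccc2n1` differs from compound 1 by hydrogen in place of methoxy on an aromatic carbon. For the measured compounds named here, none of the measured steps touches this part of the molecule, so no measured step bears on the change from compound 1 to compound 4. Because all three measured compounds sit at the limit of > 100000 nM in this assay, at which 3 of the 3 values shown sit, compound 4 is expected to sit there as well, and the estimated step that the limit leaves unreadable from compound 1 to compound 4 is expected to stay within the scatter. Compound 4 is therefore estimated at 150000 nM, in a range from 60000 nM to 400000 nM.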

Compound 4, concentration for total growth inhibition: 37000 nM
Compound 4: the middle estimate sits 4.1-fold (0.61 log units) above what was measured; the whole stated range lies above it.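

Replacing the methoxy with hydrogen, on an aromatic carbon para to a large group, gives an at least 2.7-fold lower number from compound 1 to compound 4 (0.43 log units; beyond the scatter), so this position can change the reading in this assay on these non-cancerous lung cells' growth. Until now the compounds shown could not show this, and compound 4 is the first to give a number that can be read, while the others remain at one limit: the limit of > 100000 nM in this assay, at which 3 of the 4 values shown sit. Compound 1 gives > 100000 nM, which is a limit and not a number, so the step has a known minimum but no fixed size.

Going by these compounds, it remains open whether other groups at this position, such as a hydroxyl, a chlorine, an amine or the longer ethoxy, would give a number near that of compound 4 or stay at the limit. Also open is whether the same change would lower the number in a compound with hydrogen on the selenium, like compound 2, and the compounds shown give no measured property that could explain the step.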